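From a fluoro to a methoxy group: what to expect

The source may hold more compounds than are shown below. What is called first, only, known or untested is meant among the compounds shown, and "the series" means these compounds.

Measured so far:
compound 1 `O=C(O)c1csc(-n2nc(-c3ccccc3)c3c2CCCC3)n1`, 16 nM in an assay on isolated protein for antagonist activity at prostaglandin E2 receptor EP1 subtype (Homo sapiens), read by reporter gene assay; a higher number here means a weaker inhibitor, a lower number a stronger inhibitor
compound 2 `O=C(O)c1csc(-n2nc(-c3ccccc3)c3cccnc32)n1`, 200 nM
compound 3 `O=C(O)c1csc(-n2nc(-c3ccccc3)c3ccc(F)cc32)n1`, 2 nM

Compound 3 stands lowest of the three numbers in this assay. Its nearest neighbour is compound 1, whose number is higher by a gap beyond the usual scatter, and compound 2 lies further still, also beyond the scatter. The three share the same core, and differ only in the ring fused to it and in what sits on that ring.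

Compound 4 `COc1ccc2c(-c3ccccc3)nn(-c3nc(C(=O)O)cs3)c2c1` is not yet measured. It differs from compound 3 in one place: methoxy in place of fluoro on an aromatic carbon. For the measured compounds named here, no pair among the measured compounds shows what this swap does, so the expectation rests on compound 3 alone. Because compound 3 gives 2 nM, a small loss of potency, or no change beyond the scatter, is expected. Compound 4 is thus estimated at 5 nM, within a range from 1.5 nM to 25 nM. This estimate corresponds to an expected step of a 2.5-fold higher number from compound 3 to compound 4 (0.40 log units; beyond the scatter).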

Compound 4, half-maximal inhibitory concentration: 1.1 nM
Compound 4: the middle estimate sits 4.5-fold (0.66 log units) above what was measured; the measured number lies below the stated range.
By their numbers in this assay, from the lowest: compounds 4 and 3 (each within the scatter of the next); then compound 1; then compound 2.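

In this assay, for the compounds shown here, the pair gives the first direct reading of a single swap on this aromatic carbon: methoxy in place of fluoro gives a 1.8-fold lower number from compound 3 to compound 4 (0.26 log units; within the scatter). Compound 3 and compound 4 therefore cannot be told apart, which shows that this carbon accepts methoxy, with 2 heavy atoms and 1 hydrogen-bond acceptor, as well as it accepts fluoro, with 1 heavy atom and 0 hydrogen-bond acceptors. Nothing in the data explains why the two groups read alike.

Still open, from the compounds shown here alone, is how this same carbon responds to other groups, such as a hydroxyl, an ethoxy chain, an amine or a carboxylic acid. Compound 1 and compound 2 differ from compound 3 and compound 4 in more than one place, so they cannot help settle this.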